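The compounds below may be only part of what the source reports. "The series", "measured", "known", "first", "only" and "open" are said of these compounds alone.

Measured in an ADME assay on BJ cells (Homo sapiens) for cytotoxicity, with a stated time of 72 h; a lower number here means that less compound is needed, a higher number that more compound is needed for the effect:
Compound 1 `COc1ccc(-c2nc3ccccc3s2)cc1NC(=O)c1cc([N+](=O)[O-])ccc1Cl`: > 25000 nM (a limit)
Compound 2 `O=C(Nc1cc(-c2nc3ccccc3s2)ccc1Cl)c1cc([N+](=O)[O-])ccc1Cl`: > 25000 nM (a limit)
Compound 3 `O=C(Nc1cc(C(F)(F)F)cc(C(F)(F)F)c1)c1cc([N+](=O)[O-])ccc1Cl`: 22000 nM

Compound 2 yields no number in this assay, since its > 25000 nM is a limit of the assay and not a measured value. The series offers (the limit of > 25000 nM in this assay, at which 2 of the 3 values shown sit). Among the measured compounds shown here, compound 3 lacks the core of compound 1, and compound 3 gives the only actual number, 22000 nM.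

The next compound is compound 4 `O=C(Nc1cc(-c2nc3ccccc3s2)ccc1F)c1cc([N+](=O)[O-])ccc1Cl`. The change is fluoro in place of chloro on an aromatic carbon, ortho to a large group and para to a 1,3-benzothiazol-2-yl group.

For the measured compounds named here, one measured step bears on this site, a step that the two limits leave unreadable from compound 1 to compound 2, with chloro in place of methoxy on an aromatic carbon. It has no readable size, so it gives neither a magnitude nor a direction. No shift beyond the usual scatter is therefore expected in this assay, and this expectation rests on compound 2 with its > 25000 nM, again only a limit. The expected outcome is a number no higher from compound 2 to compound 4 (the limit leaves the size open). The estimate for compound 4 is 25000 nM, with an expected range of 12000 nM to 50000 nM. A report as a limit alone would be no surprise.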

Compound 4, half-maximal effective concentration: > 25000 nM
Compound 4: a limit, no number (the forecaster's own chance of this, stated with the estimate: 65%); the middle value sits exactly at the limit.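

Compound 4 gives a limit and not a number, like compound 1 and compound 2, so no step among these three compounds can be read: the limit of > 25000 nM in this assay, at which 3 of the 4 values shown sit.

The compounds shown leave open whether methoxy, chloro or fluoro at this site makes any difference to the concentration needed in this assay.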